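This account rests on a few compounds, and the source may have more. Where it says the series, first, only, none or still open, it means among the compounds named here.

Compounds measured in a functional assay on NCI-H630 cells (Homo sapiens) for cytotoxicity, read by sulforhodamine B assay, with a stated time of 5 days; a lower number here means a stronger inhibitor, a higher number a weaker inhibitor:
- compound 1, `O=C(CCCCCc1ccccc1)N[C@H]1CCOC1=O`: > 100000 nM
- compound 2, `O=C(CCCCCCCCc1ccccc1)N[C@H]1CCOC1=O`: > 100000 nM
- compound 3, `O=C(CCCCCCCCCCc1ccccc1)N[C@H]1CCOC1=O`: 66000 nM

The value of compound 1 is a limit of this assay, not a number. The value of compound 2 is likewise a limit. Going by the values given here, compound 3 gives the only number in this assay; the other two values are limits, which is what the limit of > 100000 nM in this assay, at which 2 of the 3 values shown sit, records. Among the compounds with values here, the one measured step that bears here is an at least 1.5-fold lower number from compound 2 to compound 3 (0.18 log units; that floor lies within the scatter), a shift that itself lies within the scatter of this assay, since it starts from a limit.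

Compound 4, `O=C(CCCCCCCCCc1ccccc1)N[C@H]1CCOC1=O`, differs from compound 3 in one place: phenyl in place of benzyl on a saturated chain carbon, nine bonds along the chain from a carbonyl carbon. This shortens the chain in the same direction that led from compound 3 back toward compound 2. Compound 4 is therefore expected to sit between the two, with a step of a 1.4-fold higher number from compound 3 to compound 4 (0.13 log units; within the scatter) toward a weaker number, though a step of that size stays within the scatter. Compound 4 is estimated at 90000 nM in this assay, within a range from 40000 nM to 200000 nM, and a reading that is only a limit is quite possible.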

Compound 4, half-maximal inhibitory concentration: > 100000 nM
Compound 4: only a limit was reported (the forecaster's own chance of this, stated with the estimate: 50%); middle value at least 1.1-fold (0.04 log units) from the limit.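

In this assay compound 4 gives only a limit, > 100000 nM, and not a number. Phenyl in place of benzyl at this place gives an at least 1.5-fold higher number from compound 3 to compound 4 (0.18 log units; that floor lies within the scatter), so this single change leads back to a limit, but what can be read of the step does not go beyond the scatter, and compound 3 remains the only compound with a number. The steps between compounds whose values are both limits cannot be read, and the series now shows: the limit of > 100000 nM in this assay, at which 3 of the 4 values shown sit.

Going by these compounds alone, how far compound 4 truly lies from compound 3 remains open, since a limit gives no size for that step. Also open, going by these compounds, is whether a longer chain than that of compound 3 would give a lower number in this assay, and what an amine or a carboxylic acid in place of the phenyl would do.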